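Benzyl to 4-methylbenzyl: cytotoxicity notes on compound 3

A few compounds are considered here, and "the series" means these few. Any claim that something is new, unique, unknown or untested is made for them only; others in the source may bear on it.

Compound 1 `O=C(OC1C=CC(n2ccc(=O)n(Cc3ccccc3)c2=O)C1)c1ccccc1`: > 25000 nM (a limit)
Compound 2 `O=c1ccn(C2C=CC(O)C2)c(=O)n1Cc1ccccc1`: > 250000 nM (a limit)

In an ADME assay on CCRF-CEM cells (Homo sapiens) for cytotoxicity, with a stated time of 3 days (on this read-out lower numbers stand for higher toxicity in this test and higher numbers for lower toxicity in this test), compound 1 gives > 25000 nM, which is a limit and not a number. Among the compounds with values here, compound 2 also reaches only a limit, > 250000 nM, so the series has no numerical value so far.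

Compound 3 `Cc1ccc(Cn2c(=O)ccn(C3C=CC(OC(=O)c4ccccc4)C3)c2=O)cc1` carries methyl in place of hydrogen on an aromatic carbon, para to a large group, which turns benzyl into 4-methylbenzyl: methyl in place of hydrogen on an aromatic carbon.

Within the data shown here, the only measured step is a step that the two limits leave unreadable from compound 1 to compound 2. Among the measured compounds shown here, that step concerns the benzoyl group and not the benzyl group, so it offers no size to carry over, and no measured step touches the place that changes here. The expectation therefore rests on compound 1 alone, whose limit is > 25000 nM. No step beyond the scatter is expected in this assay, and no direction is favoured. The estimated step is a step that the limit leaves unreadable from compound 1 to compound 3. Compound 3 is expected at 30000 nM, within an estimated range of 12000 nM to 250000 nM, and will most likely be reported again only as a limit.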

Compound 3, half-maximal cytotoxic concentration: > 25000 nM
Compound 3 ended at the assay's limit; the forecaster's own chance of this, stated with the estimate: 75%; the middle value does not contradict the limit.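

In this assay compound 3 gives > 25000 nM, which is a limit and not a number. Compound 1 gives > 25000 nM, also a limit. No step can be read between compound 1 and compound 3. The compounds shown leave open whether benzyl and 4-methylbenzyl differ in cytotoxicity at all, and by how much.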